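This account rests on a few compounds, and the source may have more. Where it says the series, first, only, none or still open, it means among the compounds named here.

Compound 1 `COc1ccc(C2SCC(=O)N2CCN2CCCCC2)cc1` is, in an ADME assay on Vero cells (Chlorocebus sabaeus) for cytotoxicity, read by neutral red uptake, tested at 3150 ug/mL (a lower number here means a stronger effect, a higher number a weaker effect of the compound at the concentration tested), the higher of the two numbers recorded, giving 11%. Compound 2 `COc1cccc(C2SCC(=O)N2CCN2CCCCC2)c1` gives 6% in this assay, within the scatter of compound 1, so no order between the two can be read. Compound 3 `Cc1ccc(C2SCC(=O)N2CCN2CCCCC2)cc1` differs from compound 1 in one place: methyl in place of methoxy on an aromatic carbon. For the measured compounds named here, no step between measured compounds has been recorded, so the expectation rests on compound 1 alone; a change no larger than the scatter is expected, with no direction favoured. Compound 3 is estimated at 10%, in a range from 0% to 22%. For compound 3 the expected step is a number 1 percentage points lower from compound 1 to compound 3 (within the scatter).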

Compound 3, a percentage reported as activity, at one concentration (the size of the read-out at that concentration, not a potency): 12%
Compound 3: middle estimate off by 2 percentage points, on the low side; measured number inside the range.
By their numbers in this assay, from the lowest: compounds 2, 1 and 3 (each within the scatter of the next).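

Replacing methoxy with methyl on the aromatic carbon para to a large group gives a number 1 percentage points higher from compound 1 to compound 3 (within the scatter) in this assay, so this exchange, which removes one hydrogen-bond acceptor and one heavy atom, leaves the read-out within the scatter. For the compounds shown here, the earlier compounds held no one-place step, and this is the first one at this position. No measured evidence bears on why the read-out holds here. The compounds shown leave open whether a halogen such as chlorine, a carboxylic acid or an amine at this position would move the number beyond the scatter. They also leave open whether a longer chain there would do so.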